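The source may report more compounds than this note shows. Statements on the series, on what has been measured and on what is new or still open speak of the compounds shown alone.

Measured in a functional assay on HeLa cells (Homo sapiens) for cytotoxicity, read by MTT assay, with a stated time of 24 h; a higher number here means a weaker inhibitor, a lower number a stronger inhibitor:

- Compound 1 `COc1cc(/C=C2\CN(C)C/C(=C\c3ccccc3F)C2=O)cc(OC)c1`: 5450 nM
- Compound 2 `COc1cc(/C=C2\CN(C)C/C(=C\c3ccc(Cl)cc3Cl)C2=O)cc(OC)c1`: 7760 nM

Only these two compounds have been measured, and compound 2 lies within the scatter of compound 1. Compound 3 `COc1cc(/C=C2\CN(C)C/C(=C\c3ccc(Cl)c(Cl)c3)C2=O)cc(OC)c1` keeps the shared core and carries 3,4-dichlorophenyl in place of 2,4-dichlorophenyl, on a double-bonded chain carbon bound to a double-bonded ring carbon: 3,4-dichlorophenyl in place of 2,4-dichlorophenyl on a double-bonded chain carbon bound to a double-bonded ring carbon. Within the data shown here, one measured step bears on this place, namely a 1.4-fold higher number from compound 1 to compound 2 (0.15 log units; within the scatter), where 2,4-dichlorophenyl replaced 2-fluorophenyl. Among the measured compounds shown here, no measured pair tests the present exchange directly. For the measured compounds named here, with that single step as the only guide, no change beyond the scatter is expected in this assay. The expected step is a 1.3-fold lower number from compound 2 to compound 3 (0.11 log units; within the scatter). Compound 3 is estimated at 6000 nM, with an expected range from 2500 nM to 14000 nM.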

Compound 3, half-maximal inhibitory concentration: 6900 nM
Compound 3: middle estimate off by 1.2-fold (0.06 log units), on the low side, within the range that was stated.
By their numbers in this assay, from the lowest: compounds 1, 3 and 2 (each within the scatter of the next).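

In this assay, among these compounds, the exchange of 2,4-dichlorophenyl for 3,4-dichlorophenyl, with the same atoms joined differently, gives a first direct reading of where the two chlorines sit on this ring (a 1.1-fold lower number from compound 2 to compound 3 (0.05 log units; within the scatter)). Set against 2-fluorophenyl, 3,4-dichlorophenyl also stays close (a 1.3-fold higher number from compound 1 to compound 3 (0.10 log units; within the scatter)), so the three halogen-bearing phenyl groups on a double-bonded chain carbon bound to a double-bonded ring carbon cannot be told apart in this assay. No supporting data accompany these values to account for them.

All three groups compared here are halogen-bearing phenyl rings. Going by these compounds, it remains open whether a phenyl ring carrying a dimethylamino group or a carboxylic acid at this place would shift the number beyond the scatter.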